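Imidazoline aryl ethers: pyrrole to methylpyrazole step

The compounds below may be only part of what the source reports. "The series", "measured", "known", "first", "only" and "open" are said of these compounds alone.

compound 1, `CCN(CC)C(=O)c1ccccc1OCC1=NCCN1`: a functional assay for activation of Alpha-1D adrenergic receptor (Homo sapiens), read by calcium flux; a higher number here means that more compound is needed for the effect, a lower number that less compound is needed < 5020 nM (a limit)
compound 2, `c1c[nH]c(-c2ccccc2OCC2=NCCN2)c1`: 6.31 nM
compound 3, `Cc1ccc(-c2ccccc2OCC2=NCCN2)s1`: < 100000 nM (a limit)

For the measured compounds named here, compound 2 holds the only number in this assay; the other two values are limits, one of them the limit of < 5020 nM in this assay, at which 1 of the 3 values shown sits, and the other (the limit of < 100000 nM in this assay, at which 1 of the 3 values shown sits). Going by the values given here, the one measured step that touches compound 2, a step that the limit leaves unreadable from compound 2 to compound 3, therefore gives no readable size. Compound 4, `Cn1nccc1-c1ccccc1OCC1=NCCN1`, differs from compound 2 by 1-methyl-1H-pyrazol-5-yl in place of 1H-pyrrol-2-yl on an aromatic carbon. Among the compounds with values here, no measured step bears on this change, so the expectation rests on compound 2 alone, with wide uncertainty; some loss is expected, as a step of a 9.5-fold higher number from compound 2 to compound 4 (0.98 log units; beyond the scatter). Compound 4 is thus estimated at 60 nM, in a range from 5 nM to 1000 nM.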

Compound 4, half-maximal effective concentration: < 100000 nM
Compound 4 ended at the assay's limit (the forecaster's own chance of this, stated with the estimate: 25%); the middle value does not contradict the limit.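

Compound 4 gives < 100000 nM, which is a limit, so the steps to it from compound 2 and from compound 3 cannot be read. Left open is how compound 3 and compound 4 actually stand against compound 2.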